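Replacing the cyclopropyl group of compound 3

A few compounds are considered here, and "the series" means these few. Any claim that something is new, unique, unknown or untested is made for them only; others in the source may bear on it.

Measured in a functional assay on MCF7 cells (Homo sapiens) for cytotoxicity, read by MTT assay, with a stated time of 72 h; a lower number here means a stronger inhibitor, a higher number a weaker inhibitor:
- compound 1 `COc1ncc(-c2ccc3nc(NC(=O)N4CCCC4)nn3c2)cc1NS(=O)(=O)c1ccc(F)cc1` at 1660 nM
- compound 2 `COc1ncc(-c2ccc3nc(NC(=O)NCCN4CCCC4)nn3c2)cc1NS(=O)(=O)c1ccc(F)cc1` at 380 nM
- compound 3 `COc1ncc(-c2ccc3nc(NC(=O)NC4CC4)nn3c2)cc1NS(=O)(=O)c1ccc(F)cc1` at 300 nM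

Compound 3 stands with compound 2 at the low end of these numbers, well clear of compound 1 with a 5.5-fold lower number from compound 1 to compound 3 (0.74 log units; beyond the scatter). Compound 4 `COc1ncc(-c2ccc3nc(NC(=O)NCC(=O)N4CCCC4)nn3c2)cc1NS(=O)(=O)c1ccc(F)cc1` carries a larger group on the same nitrogen: ((pyrrolidin-1-yl)carbonyl)methyl in place of cyclopropyl on an amide-type nitrogen. The nearest evidence is a 1.3-fold lower number from compound 2 to compound 3 (0.10 log units; within the scatter), where a long side chain replaces cyclopropyl with no real change. The modest 4.4-fold lower number from compound 1 to compound 2 (0.64 log units; beyond the scatter) concerns a different change, pyrrolidin-1-yl sitting directly on the carbonyl carbon. No step beyond the scatter is therefore expected, and the expected step is a 1.5-fold higher number from compound 3 to compound 4 (0.18 log units; within the scatter). Compound 4 is estimated at 450 nM, with an expected range of 180 nM to 1200 nM.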

Compound 4, half-maximal inhibitory concentration: 2130 nM
Estimate against measurement, compound 4: 4.7-fold (0.68 log units) below; the measured number lies above the stated range.
By their numbers in this assay, from the lowest: compounds 3 and 2 (each within the scatter of the next); then compounds 1 and 4 (each within the scatter of the next).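

On this amide-type nitrogen in this assay, ((pyrrolidin-1-yl)carbonyl)methyl does not match cyclopropyl as the side chain of compound 2 did (a 7.1-fold higher number from compound 3 to compound 4 (0.85 log units; beyond the scatter)). The two pyrrolidine-bearing chains are separated by (pyrrolidin-1-yl)carbonyl in place of (pyrrolidin-1-yl)methyl alone (a 5.6-fold higher number from compound 2 to compound 4 (0.75 log units; beyond the scatter)), and compound 4 cannot be told apart from compound 1 (a 1.3-fold higher number from compound 1 to compound 4 (0.11 log units; within the scatter)). Nothing measured here explains this loss. The compounds shown leave open whether a carboxylic acid at the chain end, or a longer chain carrying the same carbonyl, would sit with compound 3 or with compound 4.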